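The compounds below may be only part of what the source reports. "The series", "measured", "known", "first", "only" and "open" are said of these compounds alone.

Compound 3 `N=C(NCc1ccccc1)[C@@H]1CCC(=O)N1Cc1ccc(F)cc1` sits at the lower end of the three numbers in a functional assay on SH-SY5Y cells (Homo sapiens) for cytotoxicity, read by MTT assay, with stated times of 8 h, 30 min and 12 h, tested at 0.5 uM (on this read-out higher numbers stand for a stronger effect at the one concentration tested and lower numbers for a weaker effect), where compound 3 gives 23.3%; its steps to the other two are within the scatter, so no order among them is claimed. Compound 1 `N=C(NCc1ccccc1)[C@@H]1CCC(=O)N1Cc1ccccc1` gives 27.9% and compound 2 `COc1ccc(CNC(=N)[C@@H]2CCC(=O)N2Cc2ccc([N+](=O)[O-])cc2)cc1` gives 25.4%. Among the compounds with values here, the only measured step, a number 4.6 percentage points lower from compound 1 to compound 3 (within the scatter), concerns fluoro for hydrogen and lies within the scatter. Compound 4 `COc1ccc(CNC(=N)[C@@H]2CCC(=O)N2Cc2ccc(F)cc2)cc1` differs from compound 3 by methoxy in place of hydrogen on an aromatic carbon. Within the data shown here, no measured step matches this change; compound 2, which also carries the methoxy group, gives a number within the scatter of compound 3. Compound 4 is therefore expected to show a number 1.7 percentage points higher from compound 3 to compound 4 (within the scatter), nothing beyond the scatter. The estimate for compound 4 is 25%, between 17% and 33%.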

Compound 4, a percentage reported as activity, at one concentration (the size of the read-out at that concentration, not a potency): 36.7%
The estimate for compound 4 lay 11.7 percentage points below the measured number; measured number above the stated range.
By their numbers in this assay, from the lowest: compounds 3, 2, 1 and 4 (each within the scatter of the next, the first and the last beyond it).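

In this assay, methoxy in place of hydrogen on an aromatic carbon, para to a large group, gives a number 13.4 percentage points higher from compound 3 to compound 4 (beyond the scatter), so this position responds where the earlier fluoro for hydrogen step did not. With methoxy present, fluoro in place of nitro gives a number 11.3 percentage points higher from compound 2 to compound 4 (beyond the scatter), so the number also depends on the second substituent. No data bear on the cause of either step. Going by these compounds, whether the methoxy step holds with hydrogen in place of the fluoro group remains open. So does whether a hydroxyl group or an amine at the same place would give a step of similar size.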